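The source may hold more compounds than are shown below. What is called first, only, known or untested is meant among the compounds shown, and "the series" means these compounds.

Compound 1 `O=C(Nc1cccc(Cl)c1)Nc1cccc(CNc2nccnc2Cl)c1`: 6810 nM
Compound 2 `CC(C)(C)c1ccc(NC(=O)Nc2cccc(CNc3nccnc3Cl)c2)cc1`: 6010 nM

Both compounds were tested in a functional assay on T-24 cells (Homo sapiens) for antiproliferative activity, read by MTT assay, with a stated time of 48 h; a higher number here means a weaker inhibitor, a lower number a stronger inhibitor. In this assay compound 1 gives 6810 nM, and compound 2 gives 6010 nM; the two numbers sit within the usual scatter of each other, so neither stands apart. Compound 3 `O=C(Nc1cccc(CNc2nccnc2Cl)c1)Nc1ccc(Cl)cc1Br` has not yet been measured. It differs from compound 1 in one place: 2-bromo-4-chlorophenyl in place of 3-chlorophenyl on an amide-type nitrogen. Among the compounds with values here, no measured pair shows what such a change does, so no step beyond the scatter is expected. The expected step is a 1.2-fold lower number from compound 1 to compound 3 (0.09 log units; within the scatter). For compound 3 the estimate is 5500 nM, with a range from 1800 nM to 17000 nM.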

Compound 3, half-maximal inhibitory concentration: 6650 nM
The estimate for compound 3 lay 1.2-fold (0.08 log units) below the measured number; the range from low to high includes it.
By their numbers in this assay, from the lowest: compounds 2, 3 and 1 (each within the scatter of the next).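

In this assay, within the data shown here, putting 2-bromo-4-chlorophenyl in place of 3-chlorophenyl on an amide-type nitrogen gives a 1.0-fold lower number from compound 1 to compound 3 (0.01 log units; within the scatter) and is the first single-place comparison available here. At this position, then, a change of substituted phenyl group that brings in a bromine leaves the number within the scatter. Nothing at hand explains this result.

As far as these compounds go, it remains open whether a group of another kind, such as an amine or a carboxylic acid on the phenyl group, would also leave the number within the scatter.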